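Nitro for amino on a fused bicyclic thiourea

This account rests on a few compounds, and the source may have more. Where it says the series, first, only, none or still open, it means among the compounds named here.

Of the compounds shown here, two of a shared core have been measured in a functional assay on HeLa cells (Homo sapiens) for cytotoxicity, read by MTT assay, with a stated time of 24 h; on this read-out lower numbers stand for stronger inhibition and higher numbers for weaker inhibition. Compound 1 `O=C(NC(=S)Nc1nc2cc(Br)ccc2s1)c1cccs1` gives 46500 nM. Compound 2 `Nc1ccc2sc(NC(=S)NC(=O)c3cccs3)nc2c1` gives 56100 nM. Among the measured compounds shown here, the only step between them, a 1.2-fold higher number from compound 1 to compound 2 (0.08 log units; within the scatter), leaves compound 2 and compound 1 within the scatter of each other, so neither stands apart on the numbers in hand. Compound 3 `O=C(NC(=S)Nc1nc2cc([N+](=O)[O-])ccc2s1)c1cccs1` has not yet been measured. It differs from compound 2 by nitro in place of amino on an aromatic carbon. For the measured compounds named here, no measured step exchanges amino for nitro; the one step available, from compound 1 to compound 2, swaps a different group at the same place and produces no change beyond the scatter in this assay. On that slim basis compound 3 is expected to stay close to compound 2, the estimated step being a 1.1-fold lower number from compound 2 to compound 3 (0.05 log units; within the scatter). The estimate for compound 3 is 50000 nM, within a range from 15000 nM to 170000 nM.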

Compound 3, half-maximal inhibitory concentration: 72600 nM
Compound 3: the middle estimate sits 1.5-fold (0.16 log units) below what was measured; the range from low to high includes it.
By their numbers in this assay, from the lowest: compounds 1, 2 and 3 (each within the scatter of the next).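

In this assay, replacing amino with nitro gives a 1.3-fold higher number from compound 2 to compound 3 (0.11 log units; within the scatter), and replacing bromo with nitro gives a 1.6-fold higher number from compound 1 to compound 3 (0.19 log units; within the scatter). This adds a third group at this place on the aromatic carbon, and it shows that even a change that brings in more heavy atoms and removes the hydrogen-bond donor of amino leaves the number within the scatter, so none of the three groups stands apart from the others. No measurement is at hand that would explain these numbers.

As far as these compounds go, it remains open whether any other group at this place, such as a carboxylic acid, a methoxy group or a longer chain, would move the number beyond the scatter. From the compounds shown here alone, it also remains open whether a change elsewhere on the shared core would do so.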